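The source may hold more compounds than are shown below. What is called first, only, known or untested is meant among the compounds shown, and "the series" means these compounds.

Measured in a physicochemical assay for solubility, read by HPLC, in phosphate buffer, with a stated time of 24 h, at pH 7.4, tested at 100 uM; a higher number here means a more soluble compound, a lower number a less soluble compound:
- compound 1 `O=C(CCCCCNc1c(Nc2ccccc2)c(=O)c1=O)NO`: 47000000 nM
- compound 2 `O=C(CCCCCNc1c(NC2CCCCC2)c(=O)c1=O)NO`: 91000000 nM
- compound 3 `COc1ccc(Nc2c(NCCCCCC(=O)NO)c(=O)c2=O)cc1`: 3300000 nM

Compound 1 stands with compound 2 at the upper end of these three numbers, and the two cannot be told apart: a 1.9-fold higher number from compound 1 to compound 2 (0.29 log units; within the scatter). Compound 3 lies well away from both, with a 14-fold lower number from compound 1 to compound 3 (1.15 log units; beyond the scatter) and a 28-fold lower number from compound 2 to compound 3 (1.44 log units; beyond the scatter).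

The next compound, compound 4 `CC(CCCCC(=O)NO)Nc1c(Nc2ccccc2)c(=O)c1=O`, carries a single change against compound 1: methyl in place of hydrogen on a saturated chain carbon bound to a nitrogen on an aromatic ring and a saturated chain carbon. Among the compounds with values here, none of the measured steps touches this saturated chain, so the evidence is only indirect. The exchange of the whole phenyl for cyclohexyl gave a 1.9-fold higher number from compound 1 to compound 2 (0.29 log units; within the scatter), which shows that a large change need not move the number. Yet the single methoxy in place of hydrogen on an aromatic carbon gave a 14-fold lower number from compound 1 to compound 3 (1.15 log units; beyond the scatter), so one added group can also matter a great deal, and a fall cannot be ruled out. With no measurement at this place, the expectation in this assay is a step no larger than the scatter, with the range left wider on the lower side. The estimate means a 1.3-fold lower number from compound 1 to compound 4 (0.13 log units; within the scatter), as an expected step. For compound 4 the expected value is 35000000 nM, with an estimated range from 12000000 nM to 80000000 nM.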

Compound 4, solubility: 93000000 nM
For compound 4 the middle estimate is 2.7-fold (0.42 log units) below the measured one; measured number outside the range, above it.
By their numbers in this assay, from the lowest: compound 3; then compounds 1, 2 and 4 (each within the scatter of the next).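

In this assay, within the data shown here, methyl in place of hydrogen on a saturated chain carbon bound to a nitrogen on an aromatic ring and a saturated chain carbon gives a 2.0-fold higher number from compound 1 to compound 4 (0.30 log units; within the scatter), which is the first direct reading at this position of the chain. Compound 4 therefore cannot be told apart from compound 1, so this single added carbon behaves differently from the methoxy on an aromatic carbon, which gave a 14-fold lower number from compound 1 to compound 3 (1.15 log units; beyond the scatter). This holds only for this one pair, and no measurement shown gives any account of why the step has this size.

The compounds shown leave open whether a group other than methyl at this same chain carbon, such as an ethyl, an amine or a carboxylic acid, would also leave the number within the scatter of compound 1. They also leave open whether the same methyl would give a similar step on compound 2 or compound 3, or on a longer chain between the shared core and the hydroxamic acid end.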